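A few compounds are considered here, and "the series" means these few. Any claim that something is new, unique, unknown or untested is made for them only; others in the source may bear on it.

Compound 1, `C[C@H](c1ccc(C(=O)NCCC(=O)O)cc1)N1C(=O)C(c2ccccc2F)=N[C@]12CC[C@@H](C(C)(C)C)CC2`: in a functional assay on CHO cells for antagonist activity at Glucagon receptor (Homo sapiens), read by cAMP accumulation, with stated times of 30 min and 45 min (on this read-out lower numbers stand for stronger inhibition and higher numbers for weaker inhibition), compound 1 gives 350 nM.
Compound 2, `CC(C)(C)CC[C@H](c1ccc(C(=O)NCc2nn[nH]n2)cc1)N1C(=O)C(c2cccc(C(F)(F)F)c2)=N[C@]12CC[C@@H](C(C)(C)C)CC2`: in this assay compound 2 gives 180 nM.
Compound 3, `CC(C)[C@H](c1ccc(C(=O)NCc2nn[nH]n2)cc1)N1C(=O)C(c2cc(Cl)cc(Cl)c2)=N[C@]12CC[C@@H](C(C)(C)C)CC2`: in this assay compound 3 gives 2200 nM.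

Compound 2 has the lowest of the three numbers. Its nearest neighbour is compound 1, whose number is higher by a margin that lies within the usual scatter, so the two cannot be ordered against each other. Compound 3 lies far higher, well beyond the scatter.

Compound 4, `CC(C)(C)CC[C@H](c1ccc(C(=O)NCc2nn[nH]n2)cc1)N1C(=O)C(c2ccc(F)cc2)=N[C@]12CC[C@@H](C(C)(C)C)CC2`, has not yet been measured. It differs from compound 2 in one place: 4-fluorophenyl in place of 3-(trifluoromethyl)phenyl on a carbon with a double bond to nitrogen. The change sits on a carbon with a double bond to nitrogen of the five-membered non-aromatic ring. Among the measured compounds shown here, no pair of measured compounds differs in this place alone, so the step has no direct precedent; the three measured compounds differ from one another both here and on the side chain. A modest step toward a higher number is expected, a 2.2-fold higher number from compound 2 to compound 4 (0.35 log units; beyond the scatter). Compound 4 is accordingly expected to give about 400 nM, in a range from 120 nM to 1500 nM.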

Compound 4, half-maximal inhibitory concentration: 240 nM
Compound 4: the middle estimate sits 1.7-fold (0.22 log units) above what was measured, and the stated range covers the measured number.
By their numbers in this assay, from the lowest: compounds 2, 4 and 1 (each within the scatter of the next); then compound 3.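

Among the compounds shown here, this is the first comparison in which only the group on the carbon with a double bond to nitrogen of the five-membered ring changes. In this assay, 4-fluorophenyl in place of 3-(trifluoromethyl)phenyl gives a step within the scatter (a 1.3-fold higher number from compound 2 to compound 4 (0.12 log units; within the scatter)), so with the rest of compound 2 held fixed, the two groups cannot be told apart at this position. Nothing available accounts for this result.

The compounds shown leave open whether the position keeps this level of inhibition with an unsubstituted phenyl, a pyridine ring or an open alkyl chain in place of these substituted phenyl groups. They also leave open whether the same exchange gives a similar step when the side chain is the shorter one of compound 3.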